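Chloro in Place of Fluoro: Expected Cytotoxicity of Compound 4

This account rests on a few compounds, and the source may have more. Where it says the series, first, only, none or still open, it means among the compounds named here.

Three compounds have been measured in a toxicity assay on THP-1 cells (Homo sapiens) for inhibition; on this read-out lower numbers stand for higher toxicity in this test and higher numbers for lower toxicity in this test:

- compound 1 `Cn1c(-c2ccccc2F)cnc1NC(=O)c1ccc(F)cc1` gives > 100000 nM
- compound 2 `COc1ccc(CNC(=O)NC(=O)c2ccc(F)cc2)cc1` gives > 50000 nM
- compound 3 `COc1ccc(-c2cnc(NC(=O)c3ccccc3Br)n2C)cc1` gives > 100000 nM

Every one of these values is a limit of the assay rather than a number. Compound 1 sits at the limit of > 100000 nM in this assay, at which 2 of the 3 values shown sit. Compound 2 sits at the limit of > 50000 nM in this assay, at which 1 of the 3 values shown sits. Compound 1 therefore stands where the measurement stops; nothing sets it apart from compound 3, and no order among the three compounds can be read from these limits.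

Compound 4 `Cn1c(-c2ccccc2Cl)cnc1NC(=O)c1ccc(F)cc1` differs from compound 1 in a single place: chloro in place of fluoro on an aromatic carbon. Among the measured compounds shown here, no measured pair of compounds in this set shows what such an exchange does in this assay. With compound 1 already at a limit, the expectation is a step of no size beyond the usual scatter, in no particular direction, so the expected step is a number no higher from compound 1 to compound 4 (the limit leaves the size open).

Compound 4 is accordingly expected to give 100000 nM, within a range of 50000 nM to 200000 nM, and the assay is likely to report only a limit again.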

Compound 4, half-maximal cytotoxic concentration: > 50000 nM
Compound 4 gave a limit, no number (the forecaster's own chance of this, stated with the estimate: 85%); the middle value is on the limit's open side.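

In this assay, compound 1 and compound 4 each give only a limit of the assay, and the step between them cannot be read. The compounds shown leave open whether chloro in place of fluoro on an aromatic carbon changes this read-out at all, and in which direction.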